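Compound 3 and a toxicity read-out held at its limit

The source may report more compounds than this note shows. Statements on the series, on what has been measured and on what is new or still open speak of the compounds shown alone.

In an ADME assay on MRC5 cells (Homo sapiens) for cytotoxicity, read by fluorescence and resazurin assay, with a stated time of 3 days (on this read-out higher numbers stand for lower toxicity in this test and lower numbers for higher toxicity in this test), compound 1 (`O=C(Nc1cc(-c2ccccn2)n[nH]1)N1CCC(c2cccc(F)c2)CC1`) gives > 64000 nM, which is a limit and not a number. Compound 2 (`O=C(Nc1cc(-c2ccccn2)n[nH]1)N1CCC(Oc2ccccc2)CC1`) gives > 64000 nM, which is also only a limit. Going by the values given here, it therefore stands with the only other measured compound: the limit of > 64000 nM in this assay, at which 2 of the 2 values shown sit.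

Compound 3 (`O=C(Nc1cc(-c2ccccn2)n[nH]1)N1CCC(c2cccc(Cl)c2)CC1`) has not yet been measured. It carries 3-chlorophenyl in place of phenoxy on a saturated ring carbon. Among the compounds with values here, the one measured step that bears on this change is a step that the two limits leave unreadable from compound 1 to compound 2, so it offers no size to carry over. Compound 1 has 3-fluorophenyl at that same carbon, and its result remains the limit of > 64000 nM. The estimated step is a number no higher from compound 2 to compound 3 (the limit leaves the size open), and none beyond the scatter is expected. For compound 3 the expected value in this assay is 64000 nM, with an estimated range from 32000 nM to 100000 nM.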

Compound 3, half-maximal cytotoxic concentration: > 64000 nM
Compound 3: no number, only a limit; the forecaster's own chance of this, stated with the estimate: 75%; the middle value sits exactly at the limit.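

Compound 1, compound 2 and compound 3 each give only a limit in this assay, so no step among them can be read: the limit of > 64000 nM in this assay, at which 3 of the 3 values shown sit.

The compounds shown leave open whether 3-fluorophenyl, phenoxy and 3-chlorophenyl differ at all in toxicity in this test.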